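The source may hold more compounds than are shown below. What is called first, only, known or untested is meant among the compounds shown, and "the series" means these compounds.

Measured so far in a functional assay on the whole organism with Rattus norvegicus as the target; on this read-out lower numbers stand for an effect already at smaller amounts and higher numbers for an effect only at larger amounts of compound
- compound 1 (`CCOC(=O)C(=O)Nc1cccc(NC)c1C#N`) gives 0.2 mg/kg
- compound 2 (`CCOC(=O)C(=O)Nc1cccc(N(C)C(C)C)c1C#N`) gives 0.3 mg/kg
- compound 3 (`CCOC(=O)C(=O)Nc1cccc(N(CC)CC)c1C#N`) gives 0.7 mg/kg

In this assay compound 3 stands highest of the three, with 0.7 mg/kg as its value. Two modest steps lead to it, one from its nearest neighbour (a 2.3-fold higher number from compound 2 to compound 3 (0.37 log units; beyond the scatter)) and one from its furthest (a 3.5-fold higher number from compound 1 to compound 3 (0.54 log units; beyond the scatter)). The remaining step (a 1.5-fold higher number from compound 1 to compound 2 (0.18 log units; within the scatter)) stays within the scatter.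

The next compound to consider is compound 4 (`CCOC(=O)C(=O)Nc1cccc(N2CCCCC2)c1C#N`). The change is (piperidin-1-yl in place of diethylamino on an aromatic carbon), that is, piperidin-1-yl in place of diethylamino on an aromatic carbon, ortho to a cyano group.

Going by the values given here, no measured compound carries a non-aromatic ring at this place, so the measured steps bear on this change only indirectly. What they do show is that, across these three compounds, replacing the amino group at this place moved the number modestly or not beyond the scatter. The largest such step is the one seen on going to compound 3 (a 3.5-fold higher number from compound 1 to compound 3 (0.54 log units; beyond the scatter)).

A step of similar or smaller size is therefore expected here, with no clear direction and probably nothing beyond the scatter. The expected step is (a 1.2-fold lower number from compound 3 to compound 4 (0.07 log units; within the scatter)) on this estimate. For compound 4 the estimated value is 0.6 mg/kg in this assay, with an expected range from 0.2 mg/kg to 1.8 mg/kg for the measurement.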

Compound 4, dose for half-maximal effect: 2.2 mg/kg
Beside the measured number, compound 4's estimate is 3.7-fold (0.56 log units) below it; measured number above the stated range.
By their numbers in this assay, from the lowest: compounds 1 and 2 (each within the scatter of the next); then compound 3; then compound 4.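

In this assay, the first ring at this place, on an aromatic carbon ortho to a cyano group, does not behave like another small variation of the open-chain amino groups: replacing diethylamino with piperidin-1-yl adds to the rise already seen along the series (a 3.1-fold higher number from compound 3 to compound 4 (0.50 log units; beyond the scatter)). Against the other two open-chain compounds the gap is wider still (a 7.3-fold higher number from compound 2 to compound 4 (0.87 log units; beyond the scatter); an 11-fold higher number from compound 1 to compound 4 (1.04 log units; beyond the scatter)), and the second of these is the only large step among the compounds shown, so this position tolerates changes in the amino group less evenly than the first three compounds suggested. Nothing at hand explains why the ring carries this cost.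

The compounds shown cannot separate the presence of a ring from its size or from the added carbon, and a pyrrolidin-1-yl or morpholin-4-yl group at the same carbon would bear directly on that question. They also leave open whether the number falls further with a plain unsubstituted amino group, or whether methylamino already marks the low end at this position.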